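From methylsulfanyl to 4-cyanobutyl on the shared core

The compounds below may be only part of what the source reports. "The series", "measured", "known", "first", "only" and "open" are said of these compounds alone.

In a physicochemical assay for solubility, in phosphate buffer, with a stated time of 18 h (on this read-out higher numbers stand for higher solubility and lower numbers for lower solubility), compound 1 `N#Cc1c(N)nc2nc(C3CCCC3)ncc2c1N` gives 89000 nM and compound 2 `CC(C)Cc1ncc2c(N)c(C#N)c(N)nc2n1` gives 268000 nM. Compound 3 `CSc1nc(C(C)(C)C)nc2nc(N)c(C#N)c(N)c12` has the lowest number of the three, at 14000 nM. Compound 4 `CC(C)(C)c1nc(CCCCC#N)c2c(N)c(C#N)c(N)nc2n1` has 4-cyanobutyl in place of methylsulfanyl on an aromatic carbon. Going by the values given here, no measured step replaces methylsulfanyl, so the data offer no direct guide to this change. Among the compounds with values here, the only measured step, a 3.0-fold higher number from compound 1 to compound 2 (0.48 log units; beyond the scatter), exchanges other groups and bears on the change only loosely, as a modest move in this assay after one exchange on an aromatic carbon. A step no larger than that one is therefore expected, possibly within the scatter. The direction leans weakly upward, with compound 3 the lowest so far at 14000 nM. The estimated step is a 1.8-fold higher number from compound 3 to compound 4 (0.25 log units; within the scatter). Compound 4 is expected at 25000 nM, with an estimated range of 6000 nM to 90000 nM.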

Compound 4, solubility: 16000 nM
Estimate against measurement, compound 4: 1.6-fold (0.19 log units) above, within the range that was stated.
By their numbers in this assay, from the lowest: compounds 3 and 4 (each within the scatter of the next); then compound 1; then compound 2.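

On an aromatic carbon next to the ring nitrogen, this assay gives the first step read at this position: a 1.1-fold higher number from compound 3 to compound 4 (0.06 log units; within the scatter) for the exchange of methylsulfanyl for 4-cyanobutyl. With the tert-butyl group held in place, this longer chain ending in a nitrile leaves the read-out within the scatter of the methylsulfanyl compound, so this exchange shows no measurable shift at this position. Nothing measured here accounts for that outcome.

From the compounds shown here alone, whether an amine or a carboxylic acid on this aromatic carbon would move the number remains open, as does whether a plain butyl chain without the nitrile would match 4-cyanobutyl. Also open, going by these compounds, is whether the same exchange would hold with cyclopentyl or isobutyl in place of the tert-butyl group.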